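The source may report more compounds than this note shows. Statements on the series, on what has been measured and on what is new or still open speak of the compounds shown alone.

Compound 1 `Clc1ccc2[nH]c(-c3cn(-c4ccccc4)nc3-c3ccccc3)nc2c1`: > 50000 nM, a limit
Compound 2 `Cc1ccc2[nH]c(-c3cn(-c4ccccc4)nc3-c3ccccc3)nc2c1`: > 50000 nM, a limit
Compound 3 `O=C(OCc1ccccc1)c1ccc2[nH]c(-c3cn(-c4ccccc4)nc3-c3ccccc3)nc2c1`: > 50000 nM, a limit

All three compounds were tested in an ADME assay on HaCaT cells (Homo sapiens) for cytotoxicity, read by MTT assay, with a stated time of 48 h (on this read-out higher numbers stand for weaker inhibition and lower numbers for stronger inhibition), and the set stands entirely at the limit of > 50000 nM in this assay, at which 3 of the 3 values shown sit. Compound 2 therefore has no number of its own here, only the limit > 50000 nM.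

Compound 4 `COc1ccc(-c2nn(-c3ccccc3)cc2-c2nc3cc(C)ccc3[nH]2)cc1` differs from compound 2 by methoxy in place of hydrogen on an aromatic carbon, which turns phenyl to 4-methoxyphenyl: methoxy in place of hydrogen on an aromatic carbon.

Among the compounds with values here, three measured steps bear on this change, though only indirectly: a step that the two limits leave unreadable from compound 1 to compound 2, a step that the two limits leave unreadable from compound 1 to compound 3 and a step that the two limits leave unreadable from compound 2 to compound 3. They exchange chloro, methyl and benzyloxycarbonyl, and none of them is a methoxy change. None has a readable size, so there is no measured size to carry over. In this assay, no step beyond the scatter is expected, and no direction can be named.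

The expectation rests on compound 2, whose value > 50000 nM is a limit. The expected step is a number no higher from compound 2 to compound 4 (the limit leaves the size open). Compound 4 is most likely to be reported only as a limit as well. If a number is obtained, the estimate for compound 4 is 50000 nM, with an expected range from 25000 nM to 100000 nM.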

Compound 4, half-maximal inhibitory concentration: > 50000 nM
Compound 4: only a limit was reported; the forecaster's own chance of this, stated with the estimate: 80%; the middle value sits exactly at the limit.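

In this assay compound 4 gives > 50000 nM, a limit. Compound 2 also stands only at a limit, so no step can be read between compound 2 and compound 4. The compounds shown leave open whether any change to the shared core would give a measurable value, and the set offers only this: the limit of > 50000 nM in this assay, at which 4 of the 4 values shown sit.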